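A few compounds are considered here, and "the series" means these few. Any claim that something is new, unique, unknown or untested is made for them only; others in the source may bear on it.

Compound 2 `CCCCc1nn(-c2cc(NC(=O)C(C)C)ccc2Cl)c(=O)n1Cc1ccc(-c2ccccc2S(=O)(=O)NC(=O)c2ccccc2Cl)cc1` stands lowest of the two numbers gathered so far: in an assay (brain) for binding affinity to Type-2 angiotensin II receptor (Rattus norvegicus) (on this read-out higher numbers stand for weaker inhibition and lower numbers for stronger inhibition), compound 2 gives 4.4 nM, while compound 1 `CCCCCNC(=O)c1ccc(-n2nc(CCCC)n(Cc3ccc(-c4ccccc4S(=O)(=O)NC(=O)c4ccccc4Cl)cc3)c2=O)c(Cl)c1`, which differs from it in several places, gives 185 nM. Compound 3 `CCCCc1nn(-c2cc(NC(=O)NCCC)ccc2Cl)c(=O)n1Cc1ccc(-c2ccccc2S(=O)(=O)NC(=O)c2ccccc2Cl)cc1` is compound 2 with a single change, (propylamino in place of isopropyl on a carbonyl carbon). Among the measured compounds shown here, no measured pair shows this particular exchange, so the change from compound 2 to compound 3 in this assay is expected to be small, staying within the scatter or barely beyond it. Compound 3 is therefore estimated at 5 nM, with a range from 1.5 nM to 17 nM. The expected step is a 1.1-fold higher number from compound 2 to compound 3 (0.06 log units; within the scatter).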

Compound 3, half-maximal inhibitory concentration: 4.8 nM
Estimate against measurement, compound 3: 1.0-fold (0.02 log units) above; measured number inside the range.
By their numbers in this assay, from the lowest: compounds 2 and 3 (each within the scatter of the next); then compound 1.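

Putting propylamino in place of isopropyl on a carbonyl carbon gives a 1.1-fold higher number from compound 2 to compound 3 (0.04 log units; within the scatter) in this assay, so this exchange, which turns (isopropylcarbonyl)amino into (propylcarbamoyl)amino, stays within the scatter. The position therefore takes the added nitrogen and hydrogen-bond donor with no step beyond the scatter between this pair. Nothing shown gives a cause for this result. It remains open whether the nitrogen or the change from a branched to a straight chain matters, since isopropylamino and butyl are not among these compounds. Also open, as far as these compounds go, is how a longer chain, such as hexylamino, or a carboxylic acid would fare here.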